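This account rests on a few compounds, and the source may have more. Where it says the series, first, only, none or still open, it means among the compounds named here.

Working notes on the series.

Compound 1 `CC1CCN(C2CCN(S(=O)(=O)c3ccc(C(C)C)cc3)CC2)CC1` has been measured in an ADME assay on HCT-116 cells (Homo sapiens) for cytotoxicity, read by CellTiter-Glo, with a stated time of 72 h; on this read-out higher numbers stand for weaker inhibition and lower numbers for stronger inhibition. In this assay compound 1 gives > 5000 nM, which is a limit of the assay and not a number. Compound 2 `Cc1cc(C)c(S(=O)(=O)N2CCC(N3CCC(C)CC3)CC2)c(C)c1` in this assay gives > 5000 nM, again a limit. Compound 3 `Cc1cccc(S(=O)(=O)N2CCC(N3CCC(C)CC3)CC2)c1` in this assay gives > 5000 nM, also a limit. Compound 1 thus stands where every measured member of the set stands: the limit of > 5000 nM in this assay, at which 3 of the 3 values shown sit. Within the data shown here, no step between measured compounds can be computed, since none of the three returns a number, and nothing in the measured set separates one aryl substitution pattern from another.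

Compound 4 `CCCOc1ccc(S(=O)(=O)N2CCC(N3CCC(C)CC3)CC2)cc1` is the next to be measured in this assay. It differs from compound 1 by propoxy in place of isopropyl on an aromatic carbon. With all three measured values sitting at the limit, no step size is available to anchor the direction of this change; no step beyond the scatter is expected in this assay. Compound 4 is therefore expected to return a limit as well, estimated at 8000 nM with a range from 3000 nM to 25000 nM. The estimate implies an expected step that the limit leaves unreadable from compound 1 to compound 4.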

Compound 4, half-maximal inhibitory concentration: > 5000 nM
Compound 4: only a limit was reported; the forecaster's own chance of this, stated with the estimate: 85%; the middle value is on the limit's open side.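

Compound 1 and compound 4 both return limits of the assay and not numbers, so no step can be read between them. The set stands as follows: the limit of > 5000 nM in this assay, at which 4 of the 4 values shown sit. The compounds shown leave open whether propoxy, isopropyl or any other aromatic substitution pattern here separates one compound from another in this assay at all.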